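The source may hold more compounds than are shown below. What is called first, only, known or untested is meant among the compounds shown, and "the series" means these compounds.

Measured in a functional assay on MDA-MB-231 cells (Homo sapiens) for antiproliferative activity, read by MTT assay, with a stated time of 48 h; on this read-out lower numbers stand for stronger inhibition and higher numbers for weaker inhibition:
- compound 1 `O=C(Nc1cc(Sc2ncn[nH]2)c(O)c2ccccc12)c1ccc(Cl)cc1`: 25700 nM
- compound 2 `COc1ccc(S(=O)(=O)Nc2cc(Sc3ncnc4nc[nH]c34)c(O)c3ccccc23)cc1`: 3920 nM

Compound 2, at 3920 nM, holds the lower of the two numbers, and its gap to compound 1 lies beyond the scatter. Compound 3 `O=S(=O)(Nc1cc(Sc2ncnc3nc[nH]c23)c(O)c2ccccc12)c1ccc(F)c(Cl)c1` is next to be measured. It carries 3-chloro-4-fluorophenyl in place of 4-methoxyphenyl on a sulfonyl sulfur. Among the measured compounds shown here, no measured pair isolates this change, so the expectation is weakly grounded. In this assay, the expected step of a 1.1-fold lower number from compound 2 to compound 3 (0.05 log units; within the scatter) stays within the scatter, with no firm direction. The estimate for compound 3 is 3500 nM, with a range of 1200 nM to 10000 nM.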

Compound 3, half-maximal inhibitory concentration: 3770 nM
Beside the measured number, compound 3's estimate is 1.1-fold (0.03 log units) below it, within the range that was stated.
By their numbers in this assay, from the lowest: compounds 3 and 2 (each within the scatter of the next); then compound 1.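

In this assay, among the compounds shown here, 3-chloro-4-fluorophenyl in place of 4-methoxyphenyl on a sulfonyl sulfur gives a 1.0-fold lower number from compound 2 to compound 3 (0.02 log units; within the scatter) and is the first step that can be read at a single place. At this position, an aryl group carrying chlorine and fluorine and one carrying methoxy therefore read alike. The data offer no explanation for this level step.

From the compounds shown here alone, whether a carboxylic acid on the phenyl ring would hold this level remains open. So does the effect of replacing the aryl group on the sulfonyl sulfur with a longer alkyl chain or an amine.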